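Swapping a nitrile for a methoxy group on the pendant ring

This account rests on a few compounds, and the source may have more. Where it says the series, first, only, none or still open, it means among the compounds named here.

Compounds with numbers so far:
compound 1 `O=c1ccc2cc(OCc3cc(-c4ccccc4Cl)no3)ccc2o1` gives 18200 nM in a functional assay on PC-3 cells (Homo sapiens) for cytotoxicity, read by MTT assay, with a stated time of 48 h; a higher number here means a weaker inhibitor, a lower number a stronger inhibitor
compound 2 `N#Cc1ccccc1-c1cc(COc2ccc3oc(=O)ccc3c2)on1` gives 13600 nM in this assay

Among these two, compound 2 holds the lower of the two numbers, but the gap to compound 1 is small: the step of a 1.3-fold lower number from compound 1 to compound 2 (0.13 log units; within the scatter) stays inside the range that repeat measurements of this kind usually scatter over, so the two compounds cannot be told apart on potency.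

Compound 3 `COc1ccccc1-c1cc(COc2ccc3oc(=O)ccc3c2)on1` has not been measured. It differs from compound 2 in one spot: methoxy in place of cyano on an aromatic carbon. Seen one bond further out, the change reads 2-cyanophenyl to 2-methoxyphenyl.

Among the compounds with values here, only one measured step exists, the swap of chloro for cyano from compound 1 to compound 2, and it moved the number hardly at all. That step does not touch a methoxy group, so it offers no direct guide, but it shows that a small change at this position left this assay unmoved. A step of about a 1.0-fold higher number from compound 2 to compound 3 (0.01 log units; within the scatter) is therefore expected, with no shift beyond the scatter. Compound 3 is expected to give roughly 14000 nM, plausibly between 5000 nM and 40000 nM.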

Compound 3, half-maximal inhibitory concentration: 22400 nM
Estimate against measurement, compound 3: 1.6-fold (0.20 log units) below; the range from low to high includes it.
By their numbers in this assay, from the lowest: compounds 2, 1 and 3 (each within the scatter of the next).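

With methoxy, this aromatic carbon, ortho to a large group, has now carried three different groups, and in this assay the change gives a 1.6-fold higher number from compound 2 to compound 3 (0.22 log units; within the scatter) and also a 1.2-fold higher number from compound 1 to compound 3 (0.09 log units; within the scatter) when chloro is the group replaced. Cyano and methoxy each count 2 heavy atoms and 1 hydrogen-bond acceptor, yet they differ in their second heavy atom and in the triple bond that only cyano has, so this step adds a less closely matched pair to the chloro-to-cyano step, and still the compounds cannot be told apart on potency. No measurement of any property of these compounds bears on this result, so it stays a plain observation about these three groups at this one position.

Still open, going by these compounds, is whether a group of another kind at this carbon, such as an amine, a carboxylic acid or a longer alkoxy chain, would move the number beyond the scatter. Also open, on these data alone, is whether chloro, cyano or methoxy would read the same on a different carbon of the pendant ring.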